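Shortening the Acid Arm on the Benzyl Nitrogen Substituent

The source may hold more compounds than are shown below. What is called first, only, known or untested is meant among the compounds shown, and "the series" means these compounds.

Two compounds that share a core differ only in the substituent on the methylated nitrogen: compound 1 `CC(C)c1onc(-c2c(Cl)cccc2Cl)c1COc1ccc(N(C)C(=O)c2cccc(C(=O)O)c2)c(C(F)(F)F)n1` and compound 2 `CC(C)c1onc(-c2c(Cl)cccc2Cl)c1COc1ccc(N(C)Cc2ccc(CCC(=O)O)cc2)c(C(F)(F)F)n1`. In an assay on isolated protein for agonist activity at Bile acid receptor (Homo sapiens), read by FRET (a lower number here means that less compound is needed, a higher number that more compound is needed for the effect), compound 1 gives 433 nM, while compound 2 gives 17 nM, the lowest of the two numbers in this assay. Among the measured compounds shown here, the single step between them, a 25-fold lower number from compound 1 to compound 2 (1.41 log units; beyond the scatter), replaced the carbonyl link and the acid arm in one stroke.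

Compound 3 `CC(C)c1onc(-c2c(Cl)cccc2Cl)c1COc1ccc(N(C)Cc2cccc(C(=O)O)c2)c(C(F)(F)F)n1` has not yet been measured in this assay. It differs from compound 2 by 3-carboxyphenyl in place of 4-(2-carboxyethyl)phenyl on a saturated chain carbon bound to a nitrogen on an aromatic ring, so it keeps the benzyl linker of compound 2 but carries the acid directly on the ring, as in compound 1. For the measured compounds named here, no measured pair isolates this acid shift alone; the one step, a 25-fold lower number from compound 1 to compound 2 (1.41 log units; beyond the scatter), mixed both changes, and because compound 1 gives 433 nM a return toward the ring-borne acid may cost some potency. For compound 3 a moderate rise is expected, a 3.5-fold higher number from compound 2 to compound 3 (0.55 log units; beyond the scatter), with an estimate of 60 nM and a range from 15 nM to 250 nM.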

Compound 3, half-maximal effective concentration: 12 nM
The estimate for compound 3 lay 5.0-fold (0.70 log units) above the measured number, outside the stated range (below it).
By their numbers in this assay, from the lowest: compounds 3 and 2 (each within the scatter of the next); then compound 1.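

Compound 1 and compound 3 carry the same 3-carboxyphenyl group and differ only in the link to the nitrogen, so this pair separates what the earlier step had mixed: in this assay the 3-carboxybenzyl group in place of the (3-carboxyphenyl)carbonyl group gives a 36-fold lower number from compound 1 to compound 3 (1.56 log units; beyond the scatter), a large step from the link alone. The change of arm on the saturated chain carbon, by contrast, gives a 1.4-fold lower number from compound 2 to compound 3 (0.15 log units; within the scatter), so with this link in place 3-carboxyphenyl and 4-(2-carboxyethyl)phenyl cannot be told apart in this read-out, although the second group has more heavy atoms and a different placement of the carboxylic acid. Nothing at hand bears on why the link counts for so much here and the arm does not.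

The compounds shown leave open whether the carbonyl link would carry the same penalty with the 4-(2-carboxyethyl)phenyl arm in place of the 3-carboxyphenyl group. They also leave open whether this tolerance extends to a longer chain ending in a carboxylic acid, or to an amine or a primary amide in place of that acid.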